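A 1,3-benzothiazol-2-yl swap on compound 1

The source may hold more compounds than are shown below. What is called first, only, known or untested is meant among the compounds shown, and "the series" means these compounds.

Among the compounds with values here, in an ADME assay on microsomes from liver (Rattus norvegicus) for metabolic stability, read by LC-MS, with a stated time of 10 min, tested at 0.5 uM (a lower number here means that less of the compound is left, a higher number that more of the compound is left), compound 1 `c1ccc2c(c1)CN[C@@H](CN(CCCN1CCNCC1)[C@H]1CCCc3cccnc31)C2` gives 100%, the highest of the three numbers measured so far. Compound 3 `c1ccc2c(c1)CN[C@@H](CN(CCN1CCNCC1)[C@H]1CCCc3cccnc31)C2` gives 62%, and compound 2 `c1ccc2c(c1)CN[C@@H](CN(CC[C@@H]1CCCNC1)[C@H]1CCCc3cccnc31)C2` gives 28%. Measured against compound 1, the data show a number 38 percentage points lower from compound 1 to compound 3 (beyond the scatter) and a number 72 percentage points lower from compound 1 to compound 2 (beyond the scatter), and between the other two they show a number 34 percentage points higher from compound 2 to compound 3 (beyond the scatter). Compound 4 `c1cnc2c(c1)CCC[C@@H]2N(CCCN1CCNCC1)Cc1nc2ccccc2s1` differs from compound 1 in one place: 1,3-benzothiazol-2-yl in place of 1,2,3,4-tetrahydroisoquinolin-3-yl on a saturated chain carbon bound to an amine nitrogen. It carries 1,3-benzothiazol-2-yl in place of 1,2,3,4-tetrahydroisoquinolin-3-yl, on a saturated chain carbon bound to an amine nitrogen. Within the data shown here, none of the measured steps touches that place, so they show only that single changes in this set can move the number a long way. Compound 1 already stands at 100%, so a lower number is expected, of a size like the smaller of the two steps away from compound 1. The expected change is a number 35 percentage points lower from compound 1 to compound 4 (beyond the scatter). For compound 4 the estimate is 65%, with an expected range from 35% to 95%.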

Compound 4, percent of the compound remaining: 21%
Compound 4: the middle estimate sits 44 percentage points above what was measured; measured number below the stated range.
By their numbers in this assay, from the lowest: compounds 4 and 2 (each within the scatter of the next); then compound 3; then compound 1.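

In this assay, within the data shown here, putting 1,3-benzothiazol-2-yl in place of 1,2,3,4-tetrahydroisoquinolin-3-yl gives a number 79 percentage points lower from compound 1 to compound 4 (beyond the scatter) and is the first measured step at this place, on a saturated chain carbon bound to an amine nitrogen. The earlier steps shown here all changed the piperazine-bearing chain, whereas this one leaves that chain as it is in compound 1, so the number can also move a long way through this second place alone. Nothing available here accounts for the size of this step or ties it to any one feature of the two groups.

The compounds shown leave open whether a 1,3-benzoxazol-2-yl or a plain phenyl at this place would give a step of similar size. They also leave open whether 1,3-benzothiazol-2-yl would have the same effect on the chain of compound 3.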